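The compounds below may be only part of what the source reports. "The series", "measured", "known", "first", "only" and "open" are said of these compounds alone.

Measured compounds in a functional assay on CRL2813 cells (Homo sapiens) for cytotoxicity, read by sulforhodamine B assay, with a stated time of 5 days; on this read-out lower numbers stand for stronger inhibition and higher numbers for weaker inhibition:
- compound 1, `O=C(Nc1ccc(I)cc1)N[C@H]1CC[C@H](Oc2ccc(F)cc2)CC1`: 10200 nM
- compound 2, `CSc1ccccc1NC(=O)N[C@H]1CC[C@H](Oc2ccc(F)cc2)CC1`: a limit of the assay, > 20000 nM
- compound 3, `O=C(Nc1ccccc1[N+](=O)[O-])N[C@H]1CC[C@H](Oc2ccc(F)cc2)CC1`: 3500 nM

Compound 3 gives the lowest number of the two numbers shown, with compound 1 nearest; the step of a 2.9-fold lower number from compound 1 to compound 3 (0.46 log units; beyond the scatter) lies beyond the scatter. Compound 2 sits at the limit (the limit of > 20000 nM in this assay, at which 1 of the 3 values shown sits), so its value is a limit and not a number.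

Compound 4, `CSc1ccc(NC(=O)N[C@H]2CC[C@H](Oc3ccc(F)cc3)CC2)cc1`, differs from compound 3 as follows: 4-(methylsulfanyl)phenyl in place of 2-nitrophenyl on an amide-type nitrogen. Among the compounds with values here, two measured steps bear on this. The step of an at least 5.7-fold lower number from compound 2 to compound 3 (0.75 log units; beyond the scatter) shows that replacing methylsulfanyl by nitro lowers the number by at least a modest amount, so the reverse exchange should raise it. The step of a 2.9-fold lower number from compound 1 to compound 3 (0.46 log units; beyond the scatter) shows that a 4-substituted phenyl (4-iodophenyl) gives a modestly higher number than 2-nitrophenyl. Both point the same way: a modest to large increase in the number from compound 3 to compound 4, and possibly a limit.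

Compound 4 is therefore expected to show a step of a 3.4-fold higher number from compound 3 to compound 4 (0.54 log units; beyond the scatter) in this assay. The estimate for compound 4 is 12000 nM, with a range from 5000 nM to 30000 nM.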

Compound 4, half-maximal inhibitory concentration: > 20000 nM
Compound 4 was reported as a limit (the forecaster's own chance of this, stated with the estimate: 30%); middle value at least 1.6-fold (0.22 log units) from the limit.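

In this assay compound 4 gives > 20000 nM, which is a limit of the assay and not a number, and the series gathers there: the limit of > 20000 nM in this assay, at which 2 of the 4 values shown sit.

On this amide-type nitrogen, 4-(methylsulfanyl)phenyl in place of 2-nitrophenyl gives an at least 5.7-fold higher number from compound 3 to compound 4 (0.75 log units; beyond the scatter), so a methylsulfanyl group on the phenyl ring has now failed to give a readable number in both compounds that carry it. Methylsulfanyl in place of iodo gives an at least 1.9-fold higher number from compound 1 to compound 4 (0.29 log units; that floor lies within the scatter), a floor that does not separate the two compounds, and the step between the two methylsulfanyl compounds, compound 2 and compound 4, cannot be read.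

Open, going by these compounds, is whether the nitro group itself sets compound 3 apart, or whether another group on the phenyl ring, such as an amine or a carboxylic acid, would give a lower number still in this assay.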